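This account rests on a few compounds, and the source may have more. Where it says the series, first, only, none or still open, it means among the compounds named here.

Working notes on the series. In a functional assay on MCF7 cells (Homo sapiens) for antiproliferative activity, read by MTT assay, with a stated time of 72 h (on this read-out lower numbers stand for stronger inhibition and higher numbers for weaker inhibition), compound 1 `O=C(Nc1ccc(Nc2nccc(NC3CCCC3)n2)cc1)Nc1ccc(Cl)c(C(F)(F)F)c1` gives 2330 nM, and compound 2 `O=C(Nc1ccc(Nc2nccc(Nc3cccc(Cl)c3)n2)cc1)Nc1ccc(Cl)c(C(F)(F)F)c1` gives 10400 nM, the higher of the two numbers. Compound 3 `O=C(Nc1ccc(Nc2nccc(Nc3ccc(Cl)cc3)n2)cc1)Nc1ccc(Cl)c(C(F)(F)F)c1` differs from compound 2 as follows: 4-chlorophenyl in place of 3-chlorophenyl on a nitrogen on an aromatic ring. Among the compounds with values here, the only measured step that bears on this is a 4.5-fold higher number from compound 1 to compound 2 (0.65 log units; beyond the scatter), and it exchanged cyclopentyl for 3-chlorophenyl at the same place. Within the data shown here, no measured step isolates a 3-chlorophenyl to 4-chlorophenyl exchange, so in this assay no change beyond the scatter is expected, in either direction. The estimated step is a 1.2-fold lower number from compound 2 to compound 3 (0.06 log units; within the scatter). Compound 3 is expected at 9000 nM, with an estimated range of 3500 nM to 22000 nM.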

Compound 3, half-maximal inhibitory concentration: 12800 nM
Beside the measured number, compound 3's estimate is 1.4-fold (0.15 log units) below it; measured number inside the range.
By their numbers in this assay, from the lowest: compound 1; then compounds 2 and 3 (each within the scatter of the next).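

In this assay, the 3-chlorophenyl and 4-chlorophenyl groups on this nitrogen cannot be told apart, with a 1.2-fold higher number from compound 2 to compound 3 (0.09 log units; within the scatter). Compound 3 also stands apart from the cyclopentyl compound, with a 5.5-fold higher number from compound 1 to compound 3 (0.74 log units; beyond the scatter), so the gap first seen with a 4.5-fold higher number from compound 1 to compound 2 (0.65 log units; beyond the scatter) is not confined to the 3-chlorophenyl group. Nothing at hand explains these numbers.

Open, as far as these compounds go, is whether an unsubstituted phenyl or a 2-chlorophenyl would match these two chlorophenyl compounds. Also open, from the compounds shown here alone, is whether cyclohexyl, cyclopropyl or a chain carrying an amine would fall nearer compound 1.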